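The source may hold more compounds than are shown below. What is called first, only, known or untested is meant among the compounds shown, and "the series" means these compounds.

Compound 1 `CC(C(=O)N1CCN(c2ccc(Cl)cc2)CC1)N1C(=O)CCC1=O`, compound 2 `CCC(C(=O)N1CCN(c2ccc(C(F)(F)F)cc2)CC1)N1C(=O)CCC1=O` and compound 3 `CCC(C(=O)N1CCN(c2ccccc2F)CC1)N1C(=O)CCC1=O` were each tested in a functional assay on the whole organism (strain Swiss) with Mus musculus as the target, in the maximal electroshock model, with a stated time of 0.5 h, at a dose of 300 mg/kg by the intraperitoneal route; on this read-out higher numbers stand for a stronger effect at the one dose given and lower numbers for a weaker effect. Compound 1 gives 100%, compound 2 gives 0% and compound 3 gives 100%. On these numbers compound 3 stands level with compound 1 at the digits shown, the two together forming the highest of the three values; its nearest neighbour is compound 1, with no change beyond the scatter, and its furthest is compound 2, which lies far lower, a gap well beyond the scatter.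

Compound 4 `CCC(C(=O)N1CCN(c2ccc(Cl)cc2)CC1)N1C(=O)CCC1=O` has not yet been measured in this assay. It differs from compound 3 in one place: 4-chlorophenyl in place of 2-fluorophenyl on an amine nitrogen in a ring. Among the measured compounds shown here, no measured pair isolates this exchange on its own, so the size of the step can only be judged from the neighbours. Compound 1 carries the same 4-chlorophenyl group and gives 100%, whereas compound 2 gives 0%, which counsels some caution about any change at this aromatic group. Weighing both, compound 4 is expected to keep most of the effect, with an expected step of a number 25 percentage points lower from compound 3 to compound 4 (beyond the scatter). The estimate for compound 4 is 75%, within a range from 25% to 100%.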

Compound 4, a percentage reported as activity, at one dose (the size of the read-out at that dose, not a potency): 0%
Estimate against measurement, compound 4: 75 percentage points above; measured number below the stated range.
By their numbers in this assay, from the lowest: compounds 2 and 4 (each within the scatter of the next); then compounds 1 and 3 (each within the scatter of the next).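

In this assay, the exchange of 2-fluorophenyl for 4-chlorophenyl on the amine nitrogen in a ring gives a number 100 percentage points lower from compound 3 to compound 4 (beyond the scatter), so this aromatic group can decide between full effect and none when the rest of the molecule stays the same. The 4-chlorophenyl group does not decide this alone, since methyl in place of hydrogen on the saturated chain carbon, with that aromatic group unchanged, gives a number 100 percentage points lower from compound 1 to compound 4 (beyond the scatter), whereas chloro in place of trifluoromethyl on an aromatic carbon gives no change at the digits printed from compound 2 to compound 4 (within the scatter), which shows that the read-out is sensitive to the side chain as well as to the aromatic group. Nothing measured here offers a cause for these steps.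

The compounds shown leave open whether the step from compound 3 to compound 4 follows from the change of halogen or from its place on the ring, as both change together, and a 4-fluorophenyl or 2-chlorophenyl group would separate the two. On these data alone, it also remains open how 2-fluorophenyl behaves on the shorter side chain of compound 1, and whether an unsubstituted phenyl group would keep the effect on either side chain.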